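A few compounds are considered here, and "the series" means these few. Any claim that something is new, unique, unknown or untested is made for them only; others in the source may bear on it.

Compound 1 `COc1cc(-n2cnc3ccc(-c4ccc([N+](=O)[O-])cc4)cc32)cc(OC)c1OC`: 8940 nM
Compound 2 `COc1cc(-n2cnc3ccc(-c4cccc(C)c4C)cc32)cc(OC)c1OC`: 9250 nM

Both values come from a functional assay on A549 cells (Homo sapiens) for antiproliferative activity, read by MTT assay, with a stated time of 72 h; a lower number here means a stronger inhibitor, a higher number a weaker inhibitor. Within the data shown here, compound 2 stands level with compound 1, the only other measured compound. Compound 3 `COc1cc(-n2cnc3ccc(-c4ccc(C)cc4)cc32)cc(OC)c1OC` has 4-methylphenyl in place of the 2,3-dimethylphenyl of compound 2 on an aromatic carbon (4-methylphenyl in place of 2,3-dimethylphenyl on an aromatic carbon). Among the measured compounds shown here, the one measured step, a 1.0-fold higher number from compound 1 to compound 2 (0.01 log units; within the scatter), changed the group at this same place and stayed within the scatter. Two compounds give only thin evidence, but no change beyond the scatter is expected in this assay. The expected result is a 1.1-fold lower number from compound 2 to compound 3 (0.04 log units; within the scatter). Compound 3 is estimated at 8500 nM, with an expected range of 3500 nM to 20000 nM.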

Compound 3, half-maximal inhibitory concentration: 1940 nM
For compound 3 the middle estimate is 4.4-fold (0.64 log units) above the measured one; the measured number lies below the stated range.
By their numbers in this assay, from the lowest: compound 3; then compounds 1 and 2 (each within the scatter of the next).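

In this assay this position proves sensitive: 4-methylphenyl in place of 2,3-dimethylphenyl gives a 4.8-fold lower number from compound 2 to compound 3 (0.68 log units; beyond the scatter) and methyl in place of nitro gives a 4.6-fold lower number from compound 1 to compound 3 (0.66 log units; beyond the scatter) in the same direction. Compound 1 and compound 2 had stood within the scatter of each other, so only compound 3 shows that the group here can shift the number. No measurement shown accounts for this shift.

Going by these compounds, it remains open whether plain phenyl would match 4-methylphenyl. On these data alone, an amine, a carboxylic acid or a longer chain such as propyl in place of that methyl also remains untested here.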